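Swapping bromo for nitro on a cytotoxic compound

The compounds below may be only part of what the source reports. "The series", "measured", "known", "first", "only" and "open" are said of these compounds alone.

In a functional assay on K562 cells (Homo sapiens) for cytotoxicity, read by MTT assay, with a stated time of 48 h (on this read-out lower numbers stand for stronger inhibition and higher numbers for weaker inhibition), two compounds have been measured so far. Compound 1 (`COc1cc(-n2c(-c3ccc(O)cc3)c[nH]c2=O)cc(OC)c1OC`) gives > 50000 nM, which is a limit of the assay and not a number. Going by the values given here, compound 2 (`COc1cc(-n2c(-c3ccc(Br)cc3)cn(C(C)=O)c2=O)cc(OC)c1OC`) gives 1000 nM, the only true number available, so it has no other exact value to be ranked against.

Compound 3 (`COc1cc(-n2c(-c3ccc([N+](=O)[O-])cc3)cn(C(C)=O)c2=O)cc(OC)c1OC`) has not yet been measured. It has nitro in place of bromo on an aromatic carbon, para to a large group (nitro in place of bromo on an aromatic carbon). Among the compounds with values here, no measured pair of compounds shows what such a swap does in this assay, so the only anchor is compound 2 at 1000 nM. The expected 1.5-fold higher number from compound 2 to compound 3 (0.18 log units; within the scatter) is no larger than the usual scatter, with no firm direction. For compound 3 the estimated value is 1500 nM, with an expected range of 300 nM to 8000 nM.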

Compound 3, half-maximal inhibitory concentration: 26600 nM
Beside the measured number, compound 3's estimate is 18-fold (1.25 log units) below it; measured number above the stated range.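

In this assay, going by these compounds alone, the change from 4-bromophenyl to 4-nitrophenyl gives the first comparison between compounds that differ in one place: a 27-fold higher number from compound 2 to compound 3 (1.42 log units; beyond the scatter). This shows that the group on this aromatic carbon, para to a large group, strongly affects the read-out, and that in this pair bromo gives much stronger inhibition than nitro. Compound 1 stands at a limit of the assay and not at a number, while compound 3 still gives a true number, so this change does not carry the compound to that limit: the limit of > 50000 nM in this assay, at which 1 of the 3 values shown sits.

As far as these compounds go, with a single swap at this position, it remains open whether nitro is especially poor here or bromo especially good. An amine or a methoxy group in the same place would help to separate these two readings, and the reason for the large step stays unknown.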